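The source may report more compounds than this note shows. Statements on the series, on what has been measured and on what is new or still open speak of the compounds shown alone.

Measured in a physicochemical assay for lipophilicity, using the shake flask method, in phosphate buffer, measured as octanol-water partition, with a stated time of 1 h, at pH 7.4; a lower number here means a more polar compound, a higher number a more lipophilic compound:
- compound 1 `CCNC(=O)Nc1cc(Br)c(-c2cncc(C(=O)O)c2)cn1` gives -1
- compound 2 `CCNC(=O)Nc1cc(-c2ccncc2)c(-c2cncc(C(=O)O)c2)cn1` gives -0.82

Compound 2 stands within the scatter of compound 1, so these numbers do not rank the two. Compound 3 `CCNC(=O)Nc1cc(-c2cccnc2)c(-c2cncc(C(=O)O)c2)cn1` changes one group of compound 2: pyridin-3-yl in place of pyridin-4-yl on an aromatic carbon with pyridin-3-yl in place of pyridin-4-yl on an aromatic carbon. Going by the values given here, the only measured step is a number 0.18 log units higher from compound 1 to compound 2 (within the scatter) and it stays within the scatter, but it replaces bromo and no measured pair tests this swap. No step beyond the scatter is therefore expected in this assay here. The expected step is a number 0.07 log units higher from compound 2 to compound 3 (within the scatter) and lies within the scatter. For compound 3 the estimated value is -0.75 with an expected range from -1.05 to -0.45 for the coming measurement.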

Compound 3, distribution coefficient: -1.5
Compound 3: middle estimate off by 0.75 log units, on the high side; the whole stated range lies above it.
By their numbers in this assay, from the lowest: compound 3; then compounds 1 and 2 (each within the scatter of the next).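

In this assay, this position opposite the ring nitrogen proves sensitive to how the pyridine is attached: with the same atoms joined differently, pyridin-3-yl in place of pyridin-4-yl gives a number 0.68 log units lower from compound 2 to compound 3 (beyond the scatter) and so moves beyond the scatter. Pyridin-3-yl in place of bromo also gives a readable step, a number 0.50 log units lower from compound 1 to compound 3 (beyond the scatter), whereas pyridin-4-yl in place of bromo stays within the scatter. Nothing at hand accounts for this difference between the two pyridines.

From the compounds shown here alone, how a pyridin-2-yl or plain phenyl group would read at this position remains open. Also open, going by these compounds, is whether the step between the pyridines would persist with an ester in place of the carboxylic acid.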